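A few compounds are considered here, and "the series" means these few. Any claim that something is new, unique, unknown or untested is made for them only; others in the source may bear on it.

Working notes on the series. Compound 3 `COc1ccc(C(=O)Nc2cccc(/C=C/C(=O)c3nc4ccccc4[nH]3)c2)cc1` in a functional assay on 143B cells (Homo sapiens) for antiproliferative activity, read by MTT assay, with a stated time of 48 h (a lower number here means a stronger inhibitor, a higher number a weaker inhibitor), gives 6330 nM. Compound 1 `Cc1ccccc1C(=O)Nc1cccc(/C=C/C(=O)c2nc3ccccc3[nH]2)c1` gives 8290 nM in this assay, and compound 2 `Cc1ccc(C(=O)Nc2cccc(/C=C/C(=O)c3nc4ccccc4[nH]3)c2)cc1` gives 6560 nM. Compound 3 holds the lowest of the three numbers, but the step of a 1.3-fold lower number from compound 1 to compound 3 (0.12 log units; within the scatter) and the step of a 1.0-fold lower number from compound 2 to compound 3 (0.02 log units; within the scatter) both sit within the scatter, as does a 1.3-fold lower number from compound 1 to compound 2 (0.10 log units; within the scatter), so no order among the three can be read from these values.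

Compound 4 `Cc1ccccc1S(=O)(=O)Nc1cccc(/C=C/C(=O)c2nc3ccccc3[nH]2)c1` differs from compound 3 by (2-methylphenyl)sulfonyl in place of (4-methoxyphenyl)carbonyl on a nitrogen on an aromatic ring. Two parts of this change can be weighed against what has been measured. Moving the methyl from where it sits in compound 1 to where it sits in compound 2 gave a 1.3-fold lower number from compound 1 to compound 2 (0.10 log units; within the scatter), within the scatter; exchanging methyl for methoxy gave a 1.0-fold lower number from compound 2 to compound 3 (0.02 log units; within the scatter), also within the scatter. Among the compounds with values here, no measured pair bears on the exchange of a carbonyl for a sulfonyl on the ring nitrogen, so nothing in the data points to a direction for that part. The expectation for compound 4 is therefore a step of a 1.1-fold higher number from compound 3 to compound 4 (0.04 log units; within the scatter) in this assay, with a wide range around it. Compound 4 is estimated at 7000 nM in this assay, between 2500 nM and 20000 nM.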

Compound 4, half-maximal inhibitory concentration: 4060 nM
Compound 4: middle estimate off by 1.7-fold (0.24 log units), on the high side, and the stated range covers the measured number.
By their numbers in this assay, from the lowest: compounds 4, 3, 2 and 1 (each within the scatter of the next, the first and the last beyond it).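

Within the data shown here, the exchange at the nitrogen on an aromatic ring now has a direct read with the 2-methylphenyl group kept: a 2.0-fold lower number from compound 1 to compound 4 (0.31 log units; beyond the scatter) in this assay is the first step beyond the scatter, though only a modest one. Among these compounds, the earlier exchanges on the carbonyl gave no such step. Against the other two carbonyl compounds, a 1.6-fold lower number from compound 3 to compound 4 (0.19 log units; within the scatter) and a 1.6-fold lower number from compound 2 to compound 4 (0.21 log units; within the scatter) both stay within the scatter, so compound 4 separates from compound 1 alone, and no general advantage of sulfonyl over carbonyl can be claimed; nothing available bears on the cause of the step.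

Still open, as far as these compounds go, is whether sulfonyl carrying 4-methylphenyl or 4-methoxyphenyl would differ from its carbonyl counterpart. Also open, from the compounds shown here alone, is how an amine or a carboxylic acid on that aromatic ring would fare in this assay.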